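Dropping one trifluoromethyl: compound 2 to compound 3

A few compounds are considered here, and "the series" means these few. Any claim that something is new, unique, unknown or untested is made for them only; others in the source may bear on it.

In a functional assay on UO-31 cells (Homo sapiens) for inhibition, read by sulforhodamine B assay, with a stated time of 48 h, tested at 0.01 uM (on this read-out lower numbers stand for a stronger effect and higher numbers for a weaker effect at the one concentration tested), compound 1 `O=C(Nc1cccc(-n2cc(-c3ccncc3)c(-c3cc(O)cc(Cl)c3)n2)c1)Nc1ccc(Cl)c(Cl)c1` gives 93%. Compound 2 `COc1cc(Cl)cc(-c2nn(-c3cccc(NC(=O)Nc4cc(C(F)(F)F)cc(C(F)(F)F)c4)c3)cc2-c2ccncc2)c1` gives 79% in this assay, the lower of the two numbers, with compound 1 standing higher by a margin beyond the scatter. Compound 3 `COc1cc(Cl)cc(-c2nn(-c3cccc(NC(=O)Nc4cccc(C(F)(F)F)c4)c3)cc2-c2ccncc2)c1` differs from compound 2 by hydrogen in place of trifluoromethyl on an aromatic carbon. Among the measured compounds shown here, no pair of measured compounds shows this change, so the expectation rests on compound 2 alone. The expected step is small, a number 5 percentage points higher from compound 2 to compound 3 (within the scatter), within the scatter and toward a weaker effect if anything. Compound 3 is estimated at 84%, within 70% to 97%.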

Compound 3, a percentage reported as activity, at one concentration (the size of the read-out at that concentration, not a potency): 91%
The estimate for compound 3 lay 7 percentage points below the measured number; the range from low to high includes it.
By their numbers in this assay, from the lowest: compound 2; then compounds 3 and 1 (each within the scatter of the next).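

In this assay, among the compounds shown here, hydrogen in place of trifluoromethyl on this aromatic carbon gives a number 12 percentage points higher from compound 2 to compound 3 (beyond the scatter), the first step that can be read at a single place. At the one concentration tested, the trifluoromethyl that leaves therefore counts towards the stronger effect of compound 2, and this position is not indifferent to the change. No measured result at hand gives a reason for this step.

Going by these compounds, it remains open whether a nitrile or an amine on this carbon would match trifluoromethyl or hydrogen. This single step also leaves open whether the change would read the same with other groups elsewhere on the shared core.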